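Aryl swap at one position: working notes

This account rests on a few compounds, and the source may have more. Where it says the series, first, only, none or still open, it means among the compounds named here.

Measured in a functional assay on MCF7 cells (Homo sapiens) for cytotoxicity, read by ELISA, with a stated time of 4 days (on this read-out higher numbers stand for weaker inhibition and lower numbers for stronger inhibition), so far:
- compound 1 `Cc1ccc(-c2cc(-c3ccoc3)cc(-c3ccc(Cl)s3)n2)o1` gives 1900 nM
- compound 2 `Cc1ccc(-c2cc(-c3ccoc3)cc(-c3ccc(Cl)s3)n2)cc1` gives 5340 nM

Compound 2 at 5340 nM is the higher of the two numbers, and compound 1 is its nearest neighbour. Compound 3 `Clc1cccc(-c2cc(-c3ccoc3)cc(-c3ccc(Cl)s3)n2)c1` differs from compound 2 by 3-chlorophenyl in place of 4-methylphenyl on an aromatic carbon on an aromatic carbon next to the ring nitrogen. Among the measured compounds shown here, the only measured step at this place is a 2.8-fold higher number from compound 1 to compound 2 (0.45 log units; beyond the scatter) and it is modest, with other groups exchanged. It gives no direction for this swap, so no step beyond the scatter is expected in this assay here. The estimated change is a 1.2-fold lower number from compound 2 to compound 3 (0.07 log units; within the scatter) and stays within the scatter. Compound 3 is estimated at 4500 nM with an expected range of 1800 nM to 11000 nM overall.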

Compound 3, half-maximal inhibitory concentration: 2920 nM
Beside the measured number, compound 3's estimate is 1.5-fold (0.19 log units) above it; measured number inside the range.
By their numbers in this assay, from the lowest: compounds 1, 3 and 2 (each within the scatter of the next, the first and the last beyond it).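

In this assay, 3-chlorophenyl in place of 4-methylphenyl gives a 1.8-fold lower number from compound 2 to compound 3 (0.26 log units; within the scatter), and in place of 5-methylfuran-2-yl it gives a 1.5-fold higher number from compound 1 to compound 3 (0.19 log units; within the scatter). The new aryl group therefore cannot be separated from either earlier group at this position, although those two groups differ beyond the scatter. No supporting data explain these steps.

From the compounds shown here alone, whether the chlorine or its placement on the phenyl ring drives the result stays open, since both change in this swap. So does the response to an amine or carboxylic acid on that ring.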